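Methyl added on the aryl ring of compound 2

The source may hold more compounds than are shown below. What is called first, only, known or untested is meant among the compounds shown, and "the series" means these compounds.

Compound 1: `Cc1ccc(-n2nc(C(C)(C)C)cc2NC(=O)Nc2ccc(Oc3ccnc4c3[nH]c(=O)n4C)cc2F)cn1` — 12.6 h
Compound 2: `Cn1c(=O)n(C)c2c(Oc3ccc(NC(=O)Nc4cc(C(C)(C)C)nn4-c4ccccc4)c(F)c3)ccnc21` — 2.1 h

Of the compounds shown here, two have been measured in an in vivo ADME assay on the whole organism (strain BALB/cAnNCrl) for metabolic stability, with Mus musculus as the target, at a dose of 10 mg/kg by the oral route; a higher number here means that the compound lasts longer, a lower number that the compound disappears faster. Compound 1 gives 12.6 h in this assay, and compound 2 gives 2.1 h, the lower of the two numbers and beyond the scatter. The two compounds differ in more than one place, so their gap cannot be tied to a single change.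

Compound 3, `Cc1ccc(-n2nc(C(C)(C)C)cc2NC(=O)Nc2ccc(Oc3ccnc4c3n(C)c(=O)n4C)cc2F)cc1`, follows from compound 2 by one change: methyl in place of hydrogen on an aromatic carbon. Within the data shown here, no measured pair shows this change alone, so its effect is unknown. The difference between compound 1 and compound 2 includes a methyl on the ring attached to the pyrazole, but also a change in the core, so it is no direct guide. Compound 3 is expected to give 3 h in this assay, within 1 h to 9 h, an expected step of a 1.4-fold higher number from compound 2 to compound 3 (0.15 log units; within the scatter) that is not clearly beyond the scatter.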

Compound 3, half-life: 9.4 h
Compound 3: the middle estimate sits 3.1-fold (0.50 log units) below what was measured; the whole stated range lies below it.
By their numbers in this assay, from the lowest: compound 2; then compounds 3 and 1 (each within the scatter of the next).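

In this assay the change from phenyl to 4-methylphenyl brings a 4.5-fold higher number from compound 2 to compound 3 (0.65 log units; beyond the scatter) and so shows that one methyl alone can move the half-life beyond the scatter. Among these compounds, this is the first pair in which the methyl stands as the only change, placed on an aromatic carbon of a six-membered aromatic ring of carbon only, para to a large group. No measurement at hand bears on why the number rises with this change.

The compounds shown leave open whether methyl is special at this place or whether another group there, such as ethyl, methoxy or chlorine, would give a similar number. They also leave open whether the same change would bring a similar step on the core of compound 1.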